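The compounds below may be only part of what the source reports. "The series", "measured", "known", "first", "only" and "open" are said of these compounds alone.

Compound 3, `COc1cc(N(C)CCN(C)C)c(NC(=O)/C=C\C(C)C)cc1Nc1nc(C)cc(-c2cn(C)c3ccc(F)cc23)n1`, gives 14000 nM in a functional assay on HepG2 cells (Homo sapiens) for antiproliferative activity, read by MTT assay, with a stated time of 72 h (on this read-out lower numbers stand for stronger inhibition and higher numbers for weaker inhibition), and stands with the highest number of the three measured compounds. Among the measured compounds shown here, its nearest neighbour is compound 2, `C=CC(=O)Nc1cc(Nc2nc(C)cc(-c3cn(C)c4ccc(F)cc34)n2)c(OC)cc1N(C)CCN(C)C`, which in this assay gives 4280 nM; the step of a 3.3-fold higher number from compound 2 to compound 3 (0.51 log units; beyond the scatter) is the only single-point change measured so far. Compound 1, `CCC/C=C\C(=O)Nc1cc(Nc2nccc(-c3cn(C)c4ccc(F)cc34)n2)c(OC)cc1N(C)CCN(C)C`, which carries the pent-1-en-1-yl chain on a core lacking the pyrimidine methyl, gives 3400 nM in this assay, so the two compounds with a plain chain or a vinyl group on the carbonyl both sit far below compound 3.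

Compound 4, `CCC/C=C\C(=O)Nc1cc(Nc2nc(C)cc(-c3cn(C)c4ccc(F)cc34)n2)c(OC)cc1N(C)CCN(C)C`, differs from compound 3 in that (propyl in place of isopropyl on a double-bonded chain carbon bound to a double-bonded chain carbon). For the measured compounds named here, no measured step describes exactly this swap of a branched for a straight chain. The step from compound 2 to compound 3 shows that adding the branched 3-methylbut-1-en-1-yl group raised the number modestly, and compound 1 shows that a pent-1-en-1-yl chain on a closely related core sits near compound 2. Compound 4 is therefore expected to move back down, with the step of a 2.5-fold lower number from compound 3 to compound 4 (0.41 log units; beyond the scatter) estimated to lie beyond the scatter. Compound 4 is estimated at 5500 nM in this assay, within a range from 2500 nM to 14000 nM.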

Compound 4, half-maximal inhibitory concentration: 12100 nM
The estimate for compound 4 lay 2.2-fold (0.34 log units) below the measured number, within the range that was stated.
By their numbers in this assay, from the lowest: compounds 1 and 2 (each within the scatter of the next); then compounds 4 and 3 (each within the scatter of the next).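

In this assay, swapping the branched chain for a straight one makes no difference that can be told apart (a 1.2-fold lower number from compound 3 to compound 4 (0.06 log units; within the scatter)), so at this place, on a double-bonded chain carbon bound to a double-bonded chain carbon, isopropyl and propyl read alike. Both chains now stand apart from the smaller vinyl group: pent-1-en-1-yl in place of vinyl (a 2.8-fold higher number from compound 2 to compound 4 (0.45 log units; beyond the scatter)) moves the number in the same direction as 3-methylbut-1-en-1-yl in place of vinyl (a 3.3-fold higher number from compound 2 to compound 3 (0.51 log units; beyond the scatter)), and both steps lie beyond the scatter. With the pent-1-en-1-yl chain held constant, methyl in place of hydrogen on an aromatic carbon also gives a step beyond the scatter (a 3.6-fold higher number from compound 1 to compound 4 (0.55 log units; beyond the scatter)), which shows that this methyl matters on its own terms in this series. Nothing available explains any of these steps.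

On these data alone, it remains open whether a cyclopropyl group or a dimethylamino group in place of propyl would stay level with compound 3 or return toward compound 2. As far as these compounds go, it is also open whether the methyl in place of hydrogen would give a similar step on a compound carrying the vinyl group.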